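Swapping the Hydroxyethyl for Methyl on an Acid

The source may report more compounds than this note shows. Statements on the series, on what has been measured and on what is new or still open speak of the compounds shown alone.

Of the compounds shown here, three sharing one core have been measured in a functional assay on the whole organism (Tail, strain ICR) with Mus musculus as the target, in the tail flick test, with a stated time of 60 min, at a dose of 25 umol/kg by the oral route; on this read-out higher numbers stand for a stronger effect at the one dose given and lower numbers for a weaker effect. Compound 1 `C[C@H](NC(=O)CN(c1nc(Cl)nc2[nH]cnc12)C1CC1)C(=O)OCc1ccccc1` gives 64.3%. Compound 2 `C[C@@H](O)[C@H](NC(=O)CN(c1nc(Cl)nc2[nH]cnc12)C1CC1)C(=O)OCc1ccccc1` gives 29.7%, and compound 3 `C[C@@H](O)[C@H](NC(=O)CN(c1nc(Cl)nc2[nH]cnc12)C1CC1)C(=O)O` gives 30.1%. On these numbers compound 3 stands second of the three: its gap to compound 2 lies within the scatter, while compound 1 sits clearly higher.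

Compound 4 `C[C@H](NC(=O)CN(c1nc(Cl)nc2[nH]cnc12)C1CC1)C(=O)O` has not yet been measured. It differs from compound 3 in one place: methyl in place of 1-hydroxyethyl on a saturated chain carbon bound to an amide-type nitrogen and a carbonyl carbon

Within the data shown here, two measured steps bear on this change. The first is the mirror image of it: a number 34.6 percentage points lower from compound 1 to compound 2 (beyond the scatter). The second tests the other variable part of the molecule, and its effect is nil: a number 0.4 percentage points higher from compound 2 to compound 3 (within the scatter). Since exchanging the benzyl for hydrogen leaves the read-out unchanged between compound 2 and compound 3, the move from compound 3 to compound 4 is expected to undo the drop seen from compound 1 to compound 2.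

For compound 4 a rise of about a number 32.9 percentage points higher from compound 3 to compound 4 (beyond the scatter) in this assay is therefore expected, with compound 4 estimated at 63%, in a range from 45% to 80%.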

Compound 4, a percentage reported as activity, at one dose (the size of the read-out at that dose, not a potency): 44.6%
Compound 4: middle estimate off by 18.4 percentage points, on the high side; measured number below the stated range.
By their numbers in this assay, from the lowest: compounds 2 and 3 (each within the scatter of the next); then compound 4; then compound 1.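

In this assay, methyl in place of 1-hydroxyethyl still gives a gain when the oxygen next to the carbonyl group carries hydrogen, with a number 14.5 percentage points higher from compound 3 to compound 4 (beyond the scatter), but this gain is clearly smaller than the one seen when that oxygen carries benzyl: the same change on two cores in this assay, a number 34.6 percentage points lower (beyond the scatter) from compound 1 to compound 2 and a number 14.5 percentage points lower (beyond the scatter) from compound 4 to compound 3, 20.1 percentage points apart, beyond the scatter of two such steps

The benzyl group also turns out to matter after all: hydrogen in its place makes no difference beside 1-hydroxyethyl, yet beside methyl it brings a number 19.7 percentage points lower from compound 1 to compound 4 (beyond the scatter), and the two results differ by more than the scatter: the same change on two cores in this assay, a number 0.4 percentage points higher (within the scatter) from compound 2 to compound 3 and a number 19.7 percentage points lower (beyond the scatter) from compound 1 to compound 4, 20.1 percentage points apart, beyond the scatter of two such steps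

Across these four compounds, then, the two places do not act independently, and the effect of a change at one place cannot be simply added to the effect of a change at the other.

The compounds shown leave open whether the loss with 1-hydroxyethyl comes from its hydroxyl or from its extra carbon, a question that an ethyl group on the same chain carbon could help to separate. They also leave open whether a small ester, such as a methyl ester, would behave like the benzyl compounds or like the free acids.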